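The source may hold more compounds than are shown below. What is called first, only, known or untested is meant among the compounds shown, and "the series" means these compounds.

Three compounds have been measured in a functional assay on NCI-H460 cells (Homo sapiens) for cytotoxicity, read by MTT assay, with a stated time of 72 h; on this read-out lower numbers stand for stronger inhibition and higher numbers for weaker inhibition:
compound 1 `CN(C)CCn1cnnc1-c1cc(Oc2ccc(NC(=O)N/N=C/c3c(Cl)cccc3Cl)cc2F)ccn1` gives 350 nM;
compound 2 `COc1ccc(/C=N/NC(=O)Nc2ccc(Oc3ccnc(-c4nncn4CCN(C)C)c3)c(F)c2)c(OC)c1` gives 1570 nM;
compound 3 `CN(C)CCn1cnnc1-c1cc(Oc2ccc(NC(=O)N/N=C/c3ccc(Cl)cc3)cc2F)ccn1` gives 320 nM.

Among these three, compound 2 stands highest, which on this read-out means the weakest inhibition of the set. Both of its neighbours lie beyond the scatter: a 4.5-fold higher number from compound 1 to compound 2 (0.65 log units; beyond the scatter) and a 4.9-fold lower number from compound 2 to compound 3 (0.69 log units; beyond the scatter), whereas a 1.1-fold lower number from compound 1 to compound 3 (0.04 log units; within the scatter). In other words, replacing the 2,4-dimethoxyphenyl with either chlorinated phenyl gave a modest gain, and the two chlorinated variants are indistinguishable.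

Compound 4 `CN(C)CCn1cnnc1-c1cc(Oc2ccc(NC(=O)N/N=C/c3ccc(O)cc3)cc2F)ccn1` is the next candidate. Relative to compound 2 the change is 4-hydroxyphenyl in place of 2,4-dimethoxyphenyl on a carbon with a double bond to nitrogen. The two steps that leave the 2,4-dimethoxyphenyl both point the same way, each by a modest amount, so a lower number than compound 2 is expected for compound 4 as well. However, no measured compound carries a hydroxyl at this position, so the size of the expected shift is uncertain and the range is kept wide. Compound 4 is therefore estimated at 600 nM, within roughly 250 nM to 1500 nM. That estimate corresponds to a 2.6-fold lower number from compound 2 to compound 4 (0.42 log units; beyond the scatter).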

Compound 4, half-maximal inhibitory concentration: 1780 nM
Compound 4: the middle estimate sits 3.0-fold (0.47 log units) below what was measured; measured number above the stated range.
By their numbers in this assay, from the lowest: compounds 3 and 1 (each within the scatter of the next); then compounds 2 and 4 (each within the scatter of the next).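

In this assay, moving from the 2,4-dimethoxyphenyl to the 4-hydroxyphenyl brings no real shift, with a 1.1-fold higher number from compound 2 to compound 4 (0.05 log units; within the scatter), so dropping the 2,4-dimethoxyphenyl does not by itself give a lower number. What separates the compounds is the group that comes in: hydroxy in place of chloro on an aromatic carbon gives a 5.6-fold higher number from compound 3 to compound 4 (0.75 log units; beyond the scatter), and 4-hydroxyphenyl in place of 2,6-dichlorophenyl gives a 5.1-fold higher number from compound 1 to compound 4 (0.71 log units; beyond the scatter), so among these four compounds only the two chlorinated ones reach the lower numbers. No outside measurement is available to explain this split.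

As far as these compounds go, whether the lower numbers depend on chlorine itself remains open, since a bromo, methyl or nitrile on this phenyl could test that. It is also unknown how an amine or a carboxylic acid on this phenyl would compare.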